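The source may report more compounds than this note shows. Statements on the series, on what has been measured and on what is new or still open speak of the compounds shown alone.

For the measured compounds named here, in a functional assay on MT4 cells (Homo sapiens) for cytotoxicity (on this read-out lower numbers stand for stronger inhibition and higher numbers for weaker inhibition), compound 1 `N#Cc1c(N)cccc1Sc1ccccc1Cl` gives 33000 nM, the only true number among the measured compounds. Compound 2 `N#Cc1c(N)cccc1[S+]([O-])c1cc(Cl)ccc1Cl` gives > 200000 nM, which is a limit of the assay and not a number. Compound 3 `COc1cccc(S(=O)(=O)c2cccc(N)c2C#N)c1` also gives only a limit, > 200000 nM. It therefore stands at the limit of > 200000 nM in this assay, at which 2 of the 3 values shown sit, and its true place on the scale is not known.

Compound 4 `N#Cc1c(N)cccc1S(=O)(=O)c1cccc(Br)c1` keeps the shared core of compound 3 and changes one substituent: bromo in place of methoxy on an aromatic carbon. This is bromo in place of methoxy on an aromatic carbon, meta to a large group. Going by the values given here, no measured pair of compounds shows what such a swap does, so any expectation for this assay remains loose. Among the compounds with values here, compound 1, at 33000 nM, shows only that a number can be reached with the shared core, and it gives modest grounds for expecting a move toward stronger inhibition. The expected change is small, an at least 1.8-fold lower number from compound 3 to compound 4 (0.25 log units; that floor lies within the scatter), and may not stand clear of the usual scatter. A further reading that returns only a limit would be no surprise. The estimated value for compound 4 is 110000 nM, with an expected range from 35000 nM to 200000 nM.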

Compound 4, half-maximal inhibitory concentration: > 200000 nM
Compound 4: no number, only a limit; the forecaster's own chance of this, stated with the estimate: 50%; at least 1.8-fold (0.25 log units) between middle value and limit.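

For the compounds shown here, compound 3 and compound 4 both return only a limit in this assay, so no step between them can be read. The compounds shown leave open how far bromo in place of methoxy on an aromatic carbon shifts the read-out, if at all, and where compound 4 truly stands on the scale, for it sits here: the limit of > 200000 nM in this assay, at which 3 of the 4 values shown sit.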